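Compound 4: a 3-fluorophenyl step in a series at limits

The source may report more compounds than this note shows. Statements on the series, on what has been measured and on what is new or still open speak of the compounds shown alone.

Measured in an ADME assay on HEK293 cells (Homo sapiens) for cytotoxicity, read by CellTiter-Glo and resazurin assay, with a stated time of 72 h (a higher number here means that more compound is needed for the effect, a lower number that less compound is needed), with all three values reported as limits:
- compound 1 `CC(C)N(Cc1cccc(OCCCCCC(=O)O)c1)C(=O)c1ccc(-c2cccc3ccccc23)cc1` gives > 26000 nM as a limit
- compound 2 `Cc1nnc(-c2cccc(-c3ccc(C(=O)N(Cc4cccc(OCCCCCC(=O)O)c4)C(C)C)cc3)c2)o1` gives > 26000 nM as a limit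
- compound 3 `CC(C)N(Cc1cccc(OCCCCCC(=O)O)c1)C(=O)c1ccc(-c2ccc3c(c2)OCCO3)cc1` gives > 21900 nM as a limit

Compound 3 gives > 21900 nM as a limit, so its standing in the series carries no number. Compound 4 `CC(C)N(Cc1cccc(OCCCCCC(=O)O)c1)C(=O)c1ccc(-c2cccc(F)c2)cc1` has 3-fluorophenyl in place of 2,3-dihydro-1,4-benzodioxin-6-yl on an aromatic carbon para to a large group, and 3-fluorophenyl in place of 2,3-dihydro-1,4-benzodioxin-6-yl on an aromatic carbon gives the count of that change. Among the measured compounds shown here, the steps that bear on it exchange the group at this same place: a step that the two limits leave unreadable from compound 1 to compound 3 and a step that the two limits leave unreadable from compound 2 to compound 3 and also a step that the two limits leave unreadable from compound 1 to compound 2 are the three available. None has a readable size, though all three groups leave the compound at a limit. An estimated step that the limit leaves unreadable from compound 3 to compound 4 is expected, which means none beyond the scatter and no direction in this assay for now. For compound 4 the expected value is 25000 nM with an estimated range from 12000 nM to 50000 nM and a report as a limit is the likelier outcome.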

Compound 4, half-maximal effective concentration: > 26000 nM
Compound 4 gave a limit, no number; the forecaster's own chance of this, stated with the estimate: 85%; middle value at least 1.0-fold (0.01 log units) away from the limit.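

Compound 4, like compound 1, compound 2 and compound 3, is reported only as a limit in this assay, so none of its steps from those compounds can be read. The compounds shown leave open whether the group exchanged at this place affects cytotoxicity at all.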